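The compounds below may be only part of what the source reports. "The series", "measured", "known", "first", "only" and "open" are said of these compounds alone.

Measured so far, each in a functional assay on T47D cells (Homo sapiens) for inhibition; a lower number here means a stronger inhibitor, a higher number a weaker inhibitor:

Compound 1, `Oc1ccc(-c2cc(-c3ccccc3C(F)(F)F)cc(-c3cccc(O)c3)n2)cc1`: 3210 nM
Compound 2, `Oc1ccc(-c2cc(-c3ccccc3C(F)(F)F)cc(-c3ccc(O)cc3)n2)cc1`: this is a limit of the assay, > 50000 nM
Compound 3, `Oc1cccc(-c2cc(-c3cccc(OC(F)(F)F)c3)cc(-c3cccc(O)c3)n2)c1`: 6740 nM

Compound 1 and compound 3 share the same kind of framework, but the difference between the two cores is not broken down here; compound 3 gives the higher of the two numbers. Going from compound 1 to compound 2, the change is 4-hydroxyphenyl in place of 3-hydroxyphenyl on an aromatic carbon and it brought an at least 15-fold higher number from compound 1 to compound 2 (1.19 log units; beyond the scatter). Since compound 2 sits at the limit of > 50000 nM in this assay, at which 1 of the 3 values shown sits, the true size of that step can only be given as a lower bound.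

Compound 4, `Oc1ccc(-c2cc(-c3cccc(OC(F)(F)F)c3)cc(-c3cccc(O)c3)n2)cc1`, has not yet been measured in this assay. It carries the same kind of change as compound 2, (4-hydroxyphenyl in place of 3-hydroxyphenyl on an aromatic carbon), but the surroundings of the place differ: in compound 1 the place is meta to a 2-(trifluoromethyl)phenyl group and meta to a 4-hydroxyphenyl group, whereas in compound 3 it is meta to a 3-hydroxyphenyl group and meta to a large group. A step of similar direction and size is expected, an 8.9-fold higher number from compound 3 to compound 4 (0.95 log units; beyond the scatter), resting on the step of an at least 15-fold higher number from compound 1 to compound 2 (1.19 log units; beyond the scatter) seen for compound 2. For compound 4 the estimated value is therefore 60000 nM, expected to lie between 15000 nM and 200000 nM, with a real chance that this assay reports only a limit.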

Compound 4, half-maximal inhibitory concentration: 5040 nM
The estimate for compound 4 lay 12-fold (1.08 log units) above the measured number; measured number outside the range, below it.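

In this assay, putting 4-hydroxyphenyl in place of 3-hydroxyphenyl gives a 1.3-fold lower number from compound 3 to compound 4 (0.13 log units; within the scatter), so on this core the change has no effect that can be told apart from the scatter. The change therefore does not carry over from one core to the other with the same outcome, and a large step on one core did not foretell the step on the other: the same change on two cores in this assay, an at least 15-fold higher number (1.19 log units; beyond the scatter) from compound 1 to compound 2 and a 1.3-fold lower number (0.13 log units; within the scatter) from compound 3 to compound 4, at least 20-fold (1.31 log units) apart, beyond the scatter of two such steps. Two pairs do not show which feature of the cores decides the outcome or predict the step on a further core, and compound 2 is recorded only at a limit: the limit of > 50000 nM in this assay, at which 1 of the 4 values shown sits.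

The compounds shown leave open how the same change would behave on other cores, and so whether either outcome is the more typical one in this series. They also leave open what happens when the hydroxyl on these phenyl rings gives way to another group, such as an amine or a carboxylic acid.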